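Nitro in Place of Hydrogen: Compound 4 from Compound 1

The compounds below may be only part of what the source reports. "The series", "measured", "known", "first", "only" and "open" are said of these compounds alone.

Compound 1 `CC1=CC[C@H](C(C)(C)NC(=S)N/N=C/c2ccccc2)CC1` gives 9900 nM in a functional assay on 786-0 cells (Homo sapiens) for inhibition, read by sulforhodamine B assay, with a stated time of 48 h (a higher number here means a weaker inhibitor of growth, a lower number a stronger inhibitor of growth), the second highest of the three numbers available. Compound 3 `CC1=CC[C@H](C(C)(C)NC(=S)N/N=C/c2cccc(Cl)c2)CC1` gives 9200 nM, and a 1.1-fold lower number from compound 1 to compound 3 (0.03 log units; within the scatter). Compound 2 `CC1=CC[C@H](C(C)(C)NC(=S)N/N=C/c2ccc(N(C)C)cc2)CC1` gives 87000 nM, and an 8.8-fold higher number from compound 1 to compound 2 (0.94 log units; beyond the scatter). Compound 4 `CC1=CC[C@H](C(C)(C)NC(=S)N/N=C/c2ccccc2[N+](=O)[O-])CC1` differs from compound 1 by nitro in place of hydrogen on an aromatic carbon. For the measured compounds named here, no measured step puts a nitro group on this ring, so the two steps from compound 1 are the only guide: the chloro step stayed within the scatter, while the dimethylamino step raised the number modestly. Compound 4 is expected to move by a 1.1-fold higher number from compound 1 to compound 4 (0.05 log units; within the scatter), a shift within the scatter or slightly upward. Compound 4 is estimated at 11000 nM, with a range from 3500 nM to 35000 nM.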

Compound 4, concentration for 50% growth inhibition: 68500 nM
For compound 4 the middle estimate is 6.2-fold (0.79 log units) below the measured one, and the stated range ends below it.
By their numbers in this assay, from the lowest: compounds 3 and 1 (each within the scatter of the next); then compounds 4 and 2 (each within the scatter of the next).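

In this assay, nitro in place of hydrogen, ortho to a large group, gives a 6.9-fold higher number from compound 1 to compound 4 (0.84 log units; beyond the scatter), so a substituent at this place on the aromatic ring can weaken growth inhibition. Alongside an 8.8-fold higher number from compound 1 to compound 2 (0.94 log units; beyond the scatter), this is a second step beyond the scatter, and chloro goes against any such trend, with a 1.1-fold lower number from compound 1 to compound 3 (0.03 log units; within the scatter). Nothing available accounts for the nitro result. The compounds shown leave open whether the change follows from the nitro group itself or from its place on the ring. They also leave open how an amine or a carboxylic acid would behave at this same place.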